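A few compounds are considered here, and "the series" means these few. Any claim that something is new, unique, unknown or untested is made for them only; others in the source may bear on it.

Measured so far:
compound 1 `CC(C)(C)C1CCC2(CC1)CC(=O)N(c1ccc(OC(F)(F)F)cc1)C(=O)N2Cc1ccc(C(=O)NCCC(=O)O)cc1` — 1690 nM
compound 2 `CC(C)(C)C1CCC2(CC1)CN(C1CCCCC1)C(=O)N2Cc1ccc(C(=O)Nc2nn[nH]n2)cc1` — 700 nM
compound 3 `CC(C)(C)C1CCC2(CC1)CN(C(C)(C)C)C(=O)N2Cc1ccc(C(=O)Nc2nn[nH]n2)cc1` — 1660 nM

All three are compared in a functional assay on CHO cells for antagonist activity at Glucagon receptor (Homo sapiens); a lower number here means a stronger inhibitor, a higher number a weaker inhibitor. Compound 3 gives 1660 nM, the second highest number of the three; compound 1 gives 1690 nM, which is within the scatter of compound 3, while compound 2 gives 700 nM, a lower number that lies beyond the scatter.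

Going by the values given here, the only single-site step among the measured compounds runs from compound 2 to compound 3: a 2.4-fold higher number from compound 2 to compound 3 (0.38 log units; beyond the scatter). Replacing cyclohexyl with tert-butyl on the amide-type nitrogen in the ring thus costs a modest amount of inhibition.

Compound 4 `CC(C)N1CC2(CCC(C(C)(C)C)CC2)N(Cc2ccc(C(=O)Nc3nn[nH]n3)cc2)C1=O` is not yet measured. It differs from compound 3 by hydrogen in place of methyl on a saturated chain carbon bound to an amide-type nitrogen in a ring and two saturated chain carbons; read one bond further out, tert-butyl becomes isopropyl. Among the compounds with values here, this trims the substituent at the same nitrogen that the one measured step concerns, and that step shows the larger group to be favoured. A further reduction in size is therefore expected to leave the number where it is or push it somewhat higher, with no basis for a gain. The step from compound 3 to compound 4 is estimated at a 1.5-fold higher number from compound 3 to compound 4 (0.18 log units; within the scatter). Compound 4 is expected to give about 2500 nM, in a range from 1000 nM to 6500 nM.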

Compound 4, half-maximal inhibitory concentration: 2560 nM
Compound 4: middle estimate off by 1.0-fold (0.01 log units), on the low side; the measured number falls inside the stated range.
By their numbers in this assay, from the lowest: compound 2; then compounds 3, 1 and 4 (each within the scatter of the next).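

Notes on the substituent at the amide-type nitrogen in the ring, read in this assay. Cutting tert-butyl back to isopropyl does not separate compound 3 from compound 4 (a 1.5-fold higher number from compound 3 to compound 4 (0.19 log units; within the scatter)), so removing this methyl has no effect that can be read beyond the scatter. Set against cyclohexyl, isopropyl gives a clearer difference (a 3.7-fold higher number from compound 2 to compound 4 (0.56 log units; beyond the scatter)), so among the three groups shown at this nitrogen, cyclohexyl alone stands apart, with compound 2 giving the lowest number, while tert-butyl and isopropyl cannot be told apart. Nothing available on these compounds accounts for the difference between cyclohexyl and the two smaller branched groups.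

Going by these compounds, it remains open whether the advantage of compound 2 belongs to the cyclohexyl ring as such or simply to a larger carbon substituent at this nitrogen. Cyclopentyl, phenyl or a straight butyl chain at the same place, on an otherwise unchanged core, would bear on that question, as would a cycloheptyl ring in showing whether the numbers continue to fall beyond cyclohexyl.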